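This account rests on a few compounds, and the source may have more. Where it says the series, first, only, none or still open, it means among the compounds named here.

Compound 1 `Cc1ccc(C(=O)NC(=S)NNc2ncnc3ccccc23)cc1`, compound 2 `COc1cc2ncnc(NNC(=S)NC(=O)c3ccccc3)c2cc1OC` and compound 3 `O=C(NC(=S)NNc1ncnc2ccccc12)c1ccc(F)cc1` share a core and were compared in a functional assay on CNE-2 cells (Homo sapiens) for cytotoxicity, read by MTT assay, with a stated time of 72 h; a lower number here means a stronger inhibitor, a higher number a weaker inhibitor. Compound 1 gives 17200 nM, compound 2 gives 8180 nM and compound 3 gives 2840 nM. Compound 2 therefore holds the second highest of the three numbers, separated from both of its neighbours beyond the scatter. Compound 4 `COc1cc2ncnc(NNC(=S)NC(=O)c3ccc(C)cc3)c2cc1OC` differs from compound 2 by methyl in place of hydrogen on an aromatic carbon. Among the compounds with values here, no measured step swaps hydrogen for methyl; the single step involving a methyl, a 6.1-fold lower number from compound 1 to compound 3 (0.78 log units; beyond the scatter), exchanges it for fluoro and bears only loosely on this change. Compound 1 carries that methyl and gives 17200 nM, the highest number shown. A small rise is therefore expected for compound 4: a 1.3-fold higher number from compound 2 to compound 4 (0.13 log units; within the scatter). Compound 4 is estimated at 11000 nM, within 4000 nM to 30000 nM.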

Compound 4, half-maximal inhibitory concentration: 33300 nM
Estimate against measurement, compound 4: 3.0-fold (0.48 log units) below, outside the stated range (above it).
By their numbers in this assay, from the lowest: compound 3; then compound 2; then compounds 1 and 4 (each within the scatter of the next).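

In this assay, methyl in place of hydrogen, phenyl to 4-methylphenyl, gives a 4.1-fold higher number from compound 2 to compound 4 (0.61 log units; beyond the scatter). The earlier compounds shown here showed methyl only in exchange for fluoro, whereas this step isolates the methyl itself and shows that adding it on this aromatic carbon, para to a large group, weakens the compound beyond the scatter. Nothing measured here accounts for this rise. The compounds shown leave open whether an ethyl group or an amine at this place would give a similar rise. They also leave open whether methyl in place of hydrogen has the same effect on the core of compound 1.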